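The compounds below may be only part of what the source reports. "The series", "measured", "known", "first", "only" and "open" are said of these compounds alone.

Compound 1 `COc1ccc(NC(=S)OCCNC(=O)C(C)(C)Oc2ccc(Cl)cc2)cc1`: 616000 nM
Compound 2 `O=C(CCCCC1CCSS1)OCCCOC(=O)c1cccnc1`: > 800000 nM (a limit of the assay, not a number)
Compound 3 `O=C(NCCOC(=S)Nc1ccccc1)c1cccnc1`: 724000 nM

In an ADME assay on HUVEC cells (Homo sapiens) for cytotoxicity, read by MTT assay, with a stated time of 48 h (on this read-out higher numbers stand for weaker inhibition and lower numbers for stronger inhibition), compound 1 at 616000 nM and compound 3 at 724000 nM lie within the usual scatter of each other. For the measured compounds named here, they are the only two true numbers in the set. Compound 2 gives only a limit, > 800000 nM.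

The next compound, compound 4 `CC(C)(Oc1ccc(Cl)cc1)C(=O)NCCOC(=S)Nc1ccc([N+](=O)[O-])cc1Cl`, has 2-chloro-4-nitrophenyl in place of 4-methoxyphenyl on an amide-type nitrogen. Going by the values given here, no two measured compounds differ in one place only, so no direct comparison gauges this change. The expectation therefore rests on compound 1 at 616000 nM and compound 3 at 724000 nM, and it is a cautious one: a small step toward a lower number in this assay, not clearly beyond the scatter. The expected change is a 1.5-fold lower number from compound 1 to compound 4 (0.19 log units; within the scatter). For compound 4 the estimated value is 400000 nM, with an expected range from 130000 nM to 800000 nM.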

Compound 4, half-maximal inhibitory concentration: 729000 nM
Compound 4: the middle estimate sits 1.8-fold (0.26 log units) below what was measured; low and high end bracket the measured number.
By their numbers in this assay, from the lowest: compounds 1, 3 and 4 (each within the scatter of the next). At a limit, above all of these: compound 2.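

For the compounds shown here, this is the first step in the set that can be read in one place. In this assay, 2-chloro-4-nitrophenyl in place of 4-methoxyphenyl on an amide-type nitrogen whose other neighbour is the thiocarbonyl carbon gives a 1.2-fold higher number from compound 1 to compound 4 (0.07 log units; within the scatter), so compound 1 and compound 4 cannot be told apart, although the two rings carry quite different groups. Compound 2 still gives only a limit of the assay and not a number, so it adds nothing to this comparison: the limit of > 800000 nM in this assay, at which 1 of the 4 values shown sits.

The compounds shown leave open whether any other group at this nitrogen would move the number beyond the scatter. A phenyl ring bearing an amine or a carboxylic acid, or a longer alkyl chain in place of the ring, could answer that.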